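The compounds below may be only part of what the source reports. "The series", "measured", "known", "first", "only" and "open" are said of these compounds alone.

Compound 1 `O=C(/C=C/c1cccc([N+](=O)[O-])c1)c1ccc(N2CCCCC2)cc1`: > 50000 nM
Compound 2 `O=C(/C=C/c1ccc([N+](=O)[O-])o1)c1ccc(-n2ccnc2)cc1`: 22200 nM

Among the measured compounds shown here, in an ADME assay on THP-1 cells (Homo sapiens) for cytotoxicity, read by resazurin assay, with a stated time of 72 h (a lower number here means that less compound is tolerated, a higher number that more compound is tolerated), compound 2 gives 22200 nM, the only actual number so far. The entry for compound 1 is a limit, not a number.

Compound 3 `O=C(/C=C/c1ccc([N+](=O)[O-])o1)c1ccc(N2CCNCC2)cc1` carries piperazin-1-yl in place of 1H-imidazol-1-yl on an aromatic carbon. For the measured compounds named here, no measured step sizes this change, so no shift beyond the scatter is expected in this assay, with a slight lean to lower values. The expected change is a 1.5-fold lower number from compound 2 to compound 3 (0.17 log units; within the scatter). Compound 3 is estimated at 15000 nM, with an expected range of 5000 nM to 45000 nM.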

Compound 3, half-maximal cytotoxic concentration: > 50000 nM
Compound 3: a limit, no number (the forecaster's own chance of this, stated with the estimate: 15%); middle value at least 3.3-fold (0.52 log units) from the limit.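

Among the compounds shown here, on the aromatic carbon para to a large group, piperazin-1-yl in place of 1H-imidazol-1-yl gives the first sized step in this assay, an at least 2.2-fold higher number from compound 2 to compound 3 (0.35 log units; beyond the scatter), and it lies beyond the scatter. On these data alone, only its lower bound can be read, and its full size stays unknown because compound 3 carries a limit, not a number: the limit of > 50000 nM in this assay, at which 2 of the 3 values shown sit.

The compounds shown leave open how large the step really is. They also leave open whether a morpholine ring or a 4-methylpiperazin-1-yl group at this place would give a similar step.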